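The compounds below may be only part of what the source reports. "The series", "measured", "known", "first", "only" and "open" are said of these compounds alone.

Values in an ADME assay on liver for metabolic stability, with Liver microsome (Homo sapiens) as the target, read by LC-MS, using microsomes; on this read-out higher numbers stand for fast clearance and lower numbers for slow clearance:

- Compound 1 `CC(C)(C)OC[C@@H](O)C(=O)N1[C@H](C(=O)NCc2cc(Cl)ccc2-n2cnnn2)C[C@@H]2C[C@@H]21` gives 21 mL.min-1.g-1
- Compound 2 `COC(C)(C)[C@@H](O)C(=O)N1C[C@H]2C[C@H]2[C@H]1C(=O)NCc1cc(Cl)ccc1-n1cnnn1` gives 23 mL.min-1.g-1
- Compound 3 `CCCC[C@@H](O)C(=O)N1N=CC[C@H]1C(=O)NCc1cc(Cl)ccc1-n1cnnn1` gives < 12 mL.min-1.g-1, which is a limit and not a number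

Compound 1, at 21 mL.min-1.g-1, and compound 2, at 23 mL.min-1.g-1, lie within the usual scatter of each other, so this assay does not separate them. Compound 3 reports only a limit and stands at the limit of < 12 mL.min-1.g-1 in this assay, at which 1 of the 3 values shown sits.

Compound 4 `O=C(NCc1cc(Cl)ccc1-n1cnnn1)[C@@H]1C[C@@H]2C[C@@H]2N1C(=O)[C@H](O)Cc1ccccn1` has not yet been measured. It keeps the core of compound 1 and alters one group: pyridin-2-yl in place of tert-butoxy on a saturated chain carbon, two bonds along the chain from a carbonyl carbon and an oxygen on a saturated carbon. In words, pyridin-2-yl takes the place of tert-butoxy on a saturated chain carbon, two bonds along the chain from a carbonyl carbon and an oxygen on a saturated carbon.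

Among the compounds with values here, no measured pair of compounds shows this change on its own, so there is no direct guide to the size of its effect. The starting point is therefore compound 1 at 21 mL.min-1.g-1, and only a small shift towards slower clearance is expected. The estimated step, a 1.3-fold lower number from compound 1 to compound 4 (0.12 log units; within the scatter), stays within the usual scatter. For compound 4 the expected value in this assay is 16 mL.min-1.g-1, with an estimated range of 12 mL.min-1.g-1 to 30 mL.min-1.g-1.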

Compound 4, intrinsic clearance in microsomes: 17 mL.min-1.g-1
Compound 4: the middle estimate sits 1.1-fold (0.03 log units) below what was measured, and the stated range covers the measured number.
By their numbers in this assay, from the lowest: compounds 4, 1 and 2 (each within the scatter of the next). At a limit, below all of these: compound 3.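

In this assay, placing pyridin-2-yl where tert-butoxy stood, on a saturated chain carbon, two bonds along the chain from a carbonyl carbon and an oxygen on a saturated carbon, gives a 1.2-fold lower number from compound 1 to compound 4 (0.09 log units; within the scatter), so the read-out does not separate these two compounds. This is the only comparison shown that isolates a change in one place, and it shows that a group with a six-membered aromatic ring can take the place of a group with no ring here without a clear shift in clearance. None of the supporting data shown bears on why the two readings match.

From the compounds shown here alone, this single swap says little about the position as a whole, so it remains open whether an amine, a carboxylic acid or a longer chain at this carbon would move clearance beyond the usual scatter. Going by these compounds, it also remains open whether the ring nitrogen matters, which a plain phenyl ring or a pyridin-4-yl group on the same carbon could help to show.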